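This account rests on a few compounds, and the source may have more. Where it says the series, first, only, none or still open, it means among the compounds named here.

Measured compounds:
compound 1 `O=C(O)Cc1sc(C(c2ccccc2)c2ccccn2)nc1-c1ccc(Cl)cc1` gives 810 nM in an in vitro assay on HEK385-7 cells for displacement of a labelled ligand from prostaglandin D2 receptor 2 (Homo sapiens); on this read-out lower numbers stand for stronger inhibition and higher numbers for weaker inhibition
compound 2 `O=C(O)Cc1sc(C(c2ccc(F)cc2)c2ccc(F)cc2)nc1-c1cccc(F)c1` gives 1.4 nM in this assay

Compound 2 has the lowest number of the two measured compounds. Within the data shown here, its only neighbour, compound 1, shows a number that is far higher; the gap between them lies well beyond the scatter, and the two differ in more than one place, so no single step can be drawn between them. Compound 3 `O=C(O)Cc1sc(C(c2ccc(F)cc2)c2ccc(F)cc2)nc1-c1ccnc(N2CCCC2)c1` is not yet measured. It departs from compound 2 by 2-(pyrrolidin-1-yl)pyridin-4-yl in place of 3-fluorophenyl on an aromatic carbon. On the basis of compound 2 alone, a moderate step toward a higher number is expected from compound 2 to compound 3, a 5.7-fold higher number from compound 2 to compound 3 (0.76 log units; beyond the scatter), since a larger group with two hydrogen-bond acceptors enters where a fluorophenyl sat. Compound 3 is expected to give about 8 nM in this assay, within a range from 1.5 nM to 50 nM.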

Compound 3, half-maximal inhibitory concentration: 230 nM
Beside the measured number, compound 3's estimate is 29-fold (1.46 log units) below it, and the stated range ends below it.
By their numbers in this assay, from the lowest: compound 2; then compound 3; then compound 1.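

In this assay, the aromatic carbon next to the ring nitrogen proves sensitive to the group it carries: 2-(pyrrolidin-1-yl)pyridin-4-yl in place of 3-fluorophenyl gives a 160-fold higher number from compound 2 to compound 3 (2.22 log units; beyond the scatter) and so a large loss of inhibition. This is the first change in a single place among the compounds shown, so it ties a large shift to this position alone, which the earlier pair, differing in more than one place, could not do. Nothing shown gives a measured reason for the size of this step.

As far as these compounds go, the change brings in two parts at once, so it remains open whether the pyridin-4-yl part or the pyrrolidin-1-yl part carries the loss. A plain pyridin-4-yl or a 2-(morpholin-4-yl)pyridin-4-yl at this position could separate the two.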